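This account rests on a few compounds, and the source may have more. Where it says the series, first, only, none or still open, it means among the compounds named here.

Measured so far:
Compound 1, `O=C1CC(c2nc(-c3cccc(Cl)c3)no2)CN1c1ccc(Cl)cc1`: 140 nM
Compound 2, `Cc1ccc(N2CC(c3nc(-c4cccc(Cl)c4)no3)CC2=O)cc1`: 630 nM

The two compounds share one core and differ only in the group carried on the aromatic ring that is attached to the amide-type nitrogen of the five-membered ring. In an in vitro functional assay on HEK293-A cells for positive allosteric modulation of metabotropic glutamate receptor 5 (Homo sapiens), read by FLIPR and calcium flux (a lower number here means that less compound is needed, a higher number that more compound is needed for the effect), compound 1 gives 140 nM. In this assay compound 2 gives 630 nM, the higher of the two numbers, so more of compound 2 is needed for the same effect; the step of a 4.5-fold higher number from compound 1 to compound 2 (0.65 log units; beyond the scatter) is beyond the scatter.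

Compound 3, `Cc1ccccc1N1CC(c2nc(-c3cccc(Cl)c3)no2)CC1=O`, has not yet been measured. It arises from compound 2 by 2-methylphenyl in place of 4-methylphenyl on an amide-type nitrogen in a ring. Among the compounds with values here, no measured step rearranges this group on the ring; the only step known, a 4.5-fold higher number from compound 1 to compound 2 (0.65 log units; beyond the scatter), shows that altering this ring changes the number modestly. On that thin basis a modest further rise is expected, with real uncertainty about direction. Compound 3 is expected to give about 1500 nM, in a range from 500 nM to 5000 nM, which would mean an estimated step of a 2.4-fold higher number from compound 2 to compound 3 (0.38 log units; beyond the scatter).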

Compound 3, half-maximal effective concentration: > 10000 nM
Compound 3: only a limit was reported; the forecaster's own chance of this, stated with the estimate: 15%; middle value at least 6.6-fold (0.82 log units) from the limit.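

Compound 3 reaches a limit of the assay, not a number, and this is the only limit among the three compounds: the limit of > 10000 nM in this assay, at which 1 of the 3 values shown sits.

Exchanging 4-methylphenyl for 2-methylphenyl keeps the same atoms and gives an at least 15-fold higher number from compound 2 to compound 3 (1.20 log units; beyond the scatter), and exchanging 4-chlorophenyl for 2-methylphenyl gives an at least 71-fold higher number from compound 1 to compound 3 (1.85 log units; beyond the scatter). Compound 1 and compound 2 had shown only that changing the group on the 4-substituted phenyl ring shifts the number modestly, whereas these large steps show that, for the ring on this amide-type nitrogen, where the methyl group sits can matter more than that exchange of methyl for chloro.

As far as these compounds go, what remains open is whether this steep rise belongs to the methyl group itself or would also appear with other groups at that place on the ring, such as the chlorine of 2-chlorophenyl or the methoxy group of 2-methoxyphenyl. Also open is how 3-methylphenyl or plain phenyl would fall relative to these compounds, and the three compounds shown give no reason for the rise.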